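Swapping a Methyl for a Chloro on the Amide Ring

The source may hold more compounds than are shown below. What is called first, only, known or untested is meant among the compounds shown, and "the series" means these compounds.

Of the compounds shown here, three sharing one core have been measured in an assay (strain Wistar) for displacement of a labelled ligand from adenosine receptor A1 (Rattus norvegicus), read by scintillation counting; on this read-out higher numbers stand for weaker inhibition and lower numbers for stronger inhibition. Compound 2 `Nc1nc(-c2ccccc2)nc2c1nnn2Cc1ccccc1` gives 5.6 nM. Placing an aryl carbonyl on its ring nitrogen raises the number greatly: compound 1 `COc1ccccc1C(=O)Nc1nc(-c2ccccc2)nc2c1nnn2Cc1ccccc1` gives 1520 nM, and compound 3 `Cc1ccc(C(=O)Nc2nc(-c3ccccc3)nc3c2nnn3Cc2ccccc2)cc1` gives 709 nM, the second highest of the three numbers, a 130-fold higher number from compound 2 to compound 3 (2.10 log units; beyond the scatter). Changing the ring on the carbonyl mattered far less, a 2.1-fold lower number from compound 1 to compound 3 (0.33 log units; beyond the scatter). Compound 4 `O=C(Nc1nc(-c2ccccc2)nc2c1nnn2Cc1ccccc1)c1ccc(Cl)cc1` differs from compound 3 by chloro in place of methyl on an aromatic carbon. Among the compounds with values here, no measured step swaps one group on that ring for another in the same place; the only related step, the change of ring on the carbonyl a 2.1-fold lower number from compound 1 to compound 3 (0.33 log units; beyond the scatter), was modest. The expected step of a 1.2-fold lower number from compound 3 to compound 4 (0.07 log units; within the scatter) is therefore small in this assay. Compound 4 is estimated at 600 nM, with a range from 250 nM to 1500 nM.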

Compound 4, inhibition constant: 108 nM
Compound 4: the middle estimate sits 5.6-fold (0.74 log units) above what was measured, and the stated range ends above it.
By their numbers in this assay, from the lowest: compound 2; then compound 4; then compound 3; then compound 1.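

Within the data shown here, the para position on this ring is more sensitive than the earlier compounds suggested: in this assay, chloro in place of methyl gives a 6.6-fold lower number from compound 3 to compound 4 (0.82 log units; beyond the scatter) even though each group has one heavy atom. The choice of ring on the carbonyl also matters more than it first appeared, with a 14-fold lower number from compound 1 to compound 4 (1.15 log units; beyond the scatter) here. Even so, the chloro compound does not recover the number of the compound without the aryl carbonyl, with a 19-fold higher number from compound 2 to compound 4 (1.29 log units; beyond the scatter) remaining. No available evidence explains why chloro and methyl differ here.

Going by these compounds, whether fluoro, an amine or a nitrile at this same ring carbon would behave like chloro or like methyl remains open.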